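This account rests on a few compounds, and the source may have more. Where it says the series, first, only, none or still open, it means among the compounds named here.

Measured in a functional assay on HeLa cells (Homo sapiens) for antiproliferative activity, read by MTT assay, with a stated time of 72 h; on this read-out lower numbers stand for stronger inhibition and higher numbers for weaker inhibition:

Compound 1 `Cn1cc(Nc2nn(Cc3ccc(C(=O)NC4CCCCC4)cc3)c(=O)c3ccccc23)cn1`: 3200 nM.
Compound 2 `Cc1noc(C)c1-c1nn(Cc2ccc(C(=O)NC3CCCC3)cc2)c(=O)c2ccccc12`: > 100000 nM (a limit, not a number).

Among the compounds with values here, the only true number in this small set belongs to compound 1, at 3200 nM. Compound 2 has no number at all. Its entry of > 100000 nM is a limit of this assay.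

Compound 3 `Cc1noc(C)c1-c1nn(Cc2ccc(C(=O)NC3CCCCC3)cc2)c(=O)c2ccccc12` carries cyclohexyl in place of cyclopentyl on an amide-type nitrogen, and it otherwise matches compound 2: cyclohexyl in place of cyclopentyl on an amide-type nitrogen. Within the data shown here, no measured pair shows this change. No step beyond the usual scatter is therefore expected in this assay, and the read-out is expected to stay weak, close to the limit of the assay. The estimated step is a number no higher from compound 2 to compound 3 (the limit leaves the size open). The expected value for compound 3 is 100000 nM, with an estimated range of 30000 nM to 300000 nM.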

Compound 3, half-maximal inhibitory concentration: > 100000 nM
Compound 3: no number, only a limit; the forecaster's own chance of this, stated with the estimate: 60%; the middle value lies on the limit itself.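

In this assay, 3,5-dimethyl-1,2-oxazol-4-yl in place of (1-methyl-1H-pyrazol-4-yl)amino on an aromatic carbon now has a lower bound on its size, with cyclohexyl held constant on the amide-type nitrogen: an at least 31-fold higher number from compound 1 to compound 3 (1.49 log units; beyond the scatter). The entry of compound 3, > 100000 nM, is a limit and not a number. Cyclohexyl in place of cyclopentyl on the amide-type nitrogen cannot be read with the 3,5-dimethyl-1,2-oxazol-4-yl group present, and all that compound 2 and compound 3 share is this: the limit of > 100000 nM in this assay, at which 2 of the 3 values shown sit.

The compounds shown leave open how this step divides between the amino nitrogen and the ring, which 1-methyl-1H-pyrazol-4-yl attached directly to the aromatic carbon would separate. Also open, from the compounds shown here alone, is whether cyclopentyl and cyclohexyl differ when (1-methyl-1H-pyrazol-4-yl)amino is present.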